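Inverting one stereocentre: compound 2 to compound 3

The source may report more compounds than this note shows. Statements on the series, on what has been measured and on what is new or still open speak of the compounds shown alone.

- compound 1 (`Cc1cc(=O)c2c(OCC3CO3)cc(OCC3CO3)cc2o1`): 12100 nM
- compound 2 (`Cc1cc(=O)c2c(OC[C@@H]3CO3)cc(OC[C@@H]3CO3)cc2o1`): 39500 nM

In a functional assay on HCT-15 cells (Homo sapiens) for antiproliferative activity, with a stated time of 48 h (on this read-out higher numbers stand for weaker inhibition and lower numbers for stronger inhibition), compound 2 stands at 39500 nM, the higher of the two numbers, with compound 1 as its nearest neighbour. Compound 3 (`Cc1cc(=O)c2c(OC[C@H]3CO3)cc(OC[C@@H]3CO3)cc2o1`) is the next structure to consider: the two compounds have the same atoms and bonds and differ only in configuration as drawn: 1 of 2 stereo elements differ; a stereocentre at a saturated ring carbon is drawn S in compound 2 and R in compound 3. Among the compounds with values here, one measured step bears on this change, a 3.3-fold higher number from compound 1 to compound 2 (0.51 log units; beyond the scatter), and what separates that pair is the fact that one of compounds 1 and 2 is drawn with a defined configuration and the other without, at the place where they differ. Within the data shown here, no measured compound has an R centre drawn, so the reading is indirect. Compound 1, at 12100 nM with no configuration drawn, suggests that moving away from the configuration of compound 2 lowers the number, so a modest drop is expected for compound 3. The expected change is a 2.2-fold lower number from compound 2 to compound 3 (0.34 log units; beyond the scatter). In this assay the estimate for compound 3 is 18000 nM, with an expected range of 6000 nM to 50000 nM.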

Compound 3, half-maximal inhibitory concentration: 9590 nM
Estimate against measurement, compound 3: 1.9-fold (0.27 log units) above; the measured number falls inside the stated range.
By their numbers in this assay, from the lowest: compounds 3 and 1 (each within the scatter of the next); then compound 2.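

In this assay, the configuration at a single saturated ring carbon now has a direct reading, a 4.1-fold lower number from compound 2 to compound 3 (0.61 log units; beyond the scatter), and nothing else in the structure changes: the fact that compounds 2 and 3 differ only in the configuration as drawn. Within the data shown here, the earlier step only set a drawn configuration against an undrawn one, whereas this one is the first to involve a centre drawn R. The step to the form with no configuration drawn stays inside the scatter, a 1.3-fold lower number from compound 1 to compound 3 (0.10 log units; within the scatter), so one centre drawn R and the other drawn S reads the same as neither centre drawn: the fact that one of compounds 1 and 3 is drawn with a defined configuration and the other without, at the place where they differ.

As far as these compounds go, the effect of the second stereocentre on its own remains open, as does the reading with both centres drawn R. It is also open whether configuration still counts when an amine replaces one of the two side chains.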